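The source may report more compounds than this note shows. Statements on the series, on what has been measured and on what is new or still open speak of the compounds shown alone.

Compound 2 `C=CC1=C(C(=O)NCc2ccccc2F)C(c2ccc(OC)cc2)OC1` is the compound from which this account starts, and it is measured in a functional assay on A549 cells (Homo sapiens) for cytotoxicity, read by MTT assay, with a stated time of 24 h; a higher number here means a weaker inhibitor, a lower number a stronger inhibitor. Compound 2 gives only a limit there, > 100000 nM. Among the measured compounds shown here, compound 1 `C=CC1=C(C(=O)NCc2ccccc2)C(c2ccc(OC)cc2)OC1` is the only other compound measured in this assay. Compound 1 also gives only a limit, > 100000 nM. For the measured compounds named here, the one step that can be drawn, a step that the two limits leave unreadable from compound 1 to compound 2, is for that reason unreadable in size. Both values sit on (the limit of > 100000 nM in this assay, at which 2 of the 2 values shown sit).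

Compound 3 `C=CC1=C(C(=O)Nc2ccc(C)cc2)C(c2ccc(OC)cc2)OC1` is not yet measured. It differs from compound 2 by 4-methylphenyl in place of 2-fluorobenzyl on an amide-type nitrogen. Going by the values given here, no measured step touches the amide-type nitrogen: the only measured step concerns a fluoro in place of hydrogen on an aromatic carbon, and its size cannot be read from two limits. There is thus no footing for expecting a step beyond the scatter in this assay, in either direction. Compound 3 is expected to give 100000 nM, within 30000 nM to 300000 nM. The expected step of a number no higher from compound 2 to compound 3 (the limit leaves the size open) is none beyond the scatter, and a further limit is the likeliest outcome.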

Compound 3, half-maximal inhibitory concentration: > 100000 nM
Compound 3 was reported as a limit; the forecaster's own chance of this, stated with the estimate: 80%; the middle value lies on the limit itself.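

In this assay compound 3 gives > 100000 nM, which is a limit. No step among compound 1, compound 2 and compound 3 can be read in size, because all three values rest on one limit: the limit of > 100000 nM in this assay, at which 3 of the 3 values shown sit.

The compounds shown leave open whether any group on the amide-type nitrogen shifts the result in this assay at all.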